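Cytotoxicity in the aryloxy series: an untested ether partner

This account rests on a few compounds, and the source may have more. Where it says the series, first, only, none or still open, it means among the compounds named here.

Of the compounds shown here, three sharing one core have been measured in an ADME assay on MT4 cells (Homo sapiens) for cytotoxicity, read by MTT assay, with a stated time of 4 days; a lower number here means that less compound is tolerated, a higher number that more compound is tolerated. Compound 1 `N#Cc1ccc(Nc2nc(Oc3c(Cl)cc(Cl)cc3Cl)c3ccccc3n2)cc1` gives 56000 nM. Compound 2 `N#Cc1ccc(Nc2nc(Oc3ccccc3Cl)c3ccccc3n2)cc1` gives 38000 nM, and compound 3 `Cc1cccc(C)c1Oc1nc(Nc2ccc(C#N)cc2)nc2ccccc12` gives 35000 nM. Compound 1 holds the highest of the three numbers, yet its distance to the others is small: a 1.5-fold lower number from compound 1 to compound 2 (0.17 log units; within the scatter) and a 1.6-fold lower number from compound 1 to compound 3 (0.20 log units; within the scatter), and between the other two, a 1.1-fold lower number from compound 2 to compound 3 (0.04 log units; within the scatter). Among the measured compounds shown here, none of these three steps leaves the scatter, so the numbers so far are best read as one level.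

Compound 4 `COc1cc(C#N)ccc1Oc1nc(Nc2ccc(C#N)cc2)nc2ccccc12` is not yet measured. It differs from compound 1 by 4-cyano-2-methoxyphenyl in place of 2,4,6-trichlorophenyl on an oxygen on an aromatic ring. For the measured compounds named here, the steps that bear on this are the two that also exchange the group on that oxygen, from compound 1 to compound 2 and from compound 1 to compound 3; both stayed within the scatter, even though the exchanged groups were unlike each other. Going by the values given here, the 4-cyano-2-methoxyphenyl group is unlike either of those, and no measured step covers a group of its kind, so the expectation rests on the flatness seen so far.

The expected step is a 1.4-fold lower number from compound 1 to compound 4 (0.15 log units; within the scatter) for compound 4, with no direction beyond the scatter. Compound 4 is estimated at 40000 nM in this assay, within 14000 nM to 110000 nM.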

Compound 4, half-maximal cytotoxic concentration: >= 140000 nM
Compound 4 ended at the assay's limit; the forecaster's own chance of this, stated with the estimate: 20%; middle value at least 3.5-fold (0.54 log units) away from the limit.
By their numbers in this assay, from the lowest: compounds 3, 2 and 1 (each within the scatter of the next). At a limit, above all of these: compound 4.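

The result for compound 4 in this assay is a limit of the assay, not a number: the limit of >= 140000 nM in this assay, at which 1 of the 4 values shown sits. Among the compounds shown here, this position is therefore not flat across all groups on the oxygen, as the exchange to 4-cyano-2-methoxyphenyl gives the first steps beyond the scatter: an at least 2.5-fold higher number from compound 1 to compound 4 (0.39 log units; beyond the scatter), an at least 3.6-fold higher number from compound 2 to compound 4 (0.56 log units; beyond the scatter) and an at least 4.0-fold higher number from compound 3 to compound 4 (0.60 log units; beyond the scatter). For the compounds shown here, the single level seen so far thus holds only for 2,4,6-trichlorophenyl, 2-chlorophenyl and 2,6-dimethylphenyl, while the one group here carrying a triple bond outside aromatic rings and hydrogen-bond acceptors stands apart from all three.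

The nitrile and the methoxy enter together in one group, so the compounds shown cannot assign the shift to either of them, and a phenyl ring carrying only one of the two would be needed to separate them. Going by these compounds, it also remains open whether the shift extends to other groups on this ring, such as an amine or a carboxylic acid, and how far the true value of compound 4 lies past the limit.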